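Sulfone aryl swap on the shared core: compound 3 to compound 4

A few compounds are considered here, and "the series" means these few. Any claim that something is new, unique, unknown or untested is made for them only; others in the source may bear on it.

Measured so far:
compound 1 `Cc1ccc(S(=O)(=O)c2cnc3cc(F)ccc3c2-c2ccc(F)cc2)cc1C`: 9.25 mL/min
compound 2 `N#Cc1cccc(S(=O)(=O)c2cnc3cc(F)ccc3c2-c2cccc(Cl)c2)c1`: 0.99 mL/min
compound 3 `O=S(=O)(c1ccc(F)c(F)c1)c1cnc2cc(F)ccc2c1-c1cccc(Cl)c1`: 0.38 mL/min

In an ADME assay on microsomes from liver (Homo sapiens) for metabolic stability, tested at 2.5 uM (on this read-out higher numbers stand for fast clearance and lower numbers for slow clearance), compound 3 stands lowest of the three; compound 2 is nearest, compound 1 furthest, and both gaps lie beyond the scatter. Compound 4 `Cc1ccc(S(=O)(=O)c2cnc3cc(F)ccc3c2-c2cccc(Cl)c2)cc1C` differs from compound 3 only in the group on the sulfonyl sulfur (3,4-dimethylphenyl in place of 3,4-difluorophenyl on a sulfonyl sulfur). Among the compounds with values here, the only single-point step recorded on that position is a 2.6-fold lower number from compound 2 to compound 3 (0.42 log units; beyond the scatter), a modest move. Compound 1 carries the same 3,4-dimethylphenyl as compound 4 but a different other aryl; in this assay compound 1 gives 9.25 mL/min, far above compound 3. Taken together, an increase in this assay is expected for compound 4, larger than the recorded step. Compound 4 is therefore estimated at 4.5 mL/min, between 1.5 mL/min and 12 mL/min, a step of a 12-fold higher number from compound 3 to compound 4 (1.07 log units; beyond the scatter) expected from compound 3.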

Compound 4, intrinsic clearance in a liver preparation (reported as CLH), per the amount of preparation that the assay uses: 4.01 mL/min
Beside the measured number, compound 4's estimate is 1.1-fold (0.05 log units) above it; the measured number falls inside the stated range.
By their numbers in this assay, from the lowest: compound 3; then compound 2; then compound 4; then compound 1.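

In this assay, with 3-chlorophenyl held constant, the group on the sulfonyl sulfur alone gives an 11-fold higher number from compound 3 to compound 4 (1.02 log units; beyond the scatter) and a 4.1-fold higher number from compound 2 to compound 4 (0.61 log units; beyond the scatter), so 3,4-dimethylphenyl stands highest of the three groups compared there. With 3,4-dimethylphenyl held constant, the other aryl also moves the number, giving a 2.3-fold lower number from compound 1 to compound 4 (0.36 log units; beyond the scatter), the first single-change read at that place. Nothing available accounts for these steps.

Still open, as far as these compounds go, is whether 3,4-difluorophenyl keeps its low number when paired with 4-fluorophenyl. Also open, from the compounds shown here alone, is where a sulfonyl aryl carrying an amine or a carboxylic acid would fall.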